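This account rests on a few compounds, and the source may have more. Where it says the series, first, only, none or still open, it means among the compounds named here.

Compound 1 `Nc1nc(Cl)c2ncn([C@H]3O[C@@H](CO)C=C3F)c2n1` was examined in a functional assay on CCRF-CEM cells (Homo sapiens) for inhibition; on this read-out higher numbers stand for weaker inhibition and lower numbers for stronger inhibition. For compound 1 the result is only a limit of the assay, > 100000 nM. Compound 2 `Nc1ccn([C@H]2O[C@@H](CO)C=C2F)c(=O)n1` likewise gives only a limit in this assay, > 100000 nM. Both results sit at the limit of > 100000 nM in this assay, at which 2 of the 2 values shown sit, so compound 1 cannot be ranked against compound 2 on these numbers. Compound 3 `Nc1nc(O)c2ncn([C@H]3O[C@@H](CO)C=C3F)c2n1` differs from compound 1 by hydroxy in place of chloro on an aromatic carbon. Within the data shown here, no measured pair of compounds shows a change of this kind, so no step beyond the scatter is expected, and the step of a number no higher from compound 1 to compound 3 (the limit leaves the size open) is estimated to stay small. Compound 3 is therefore estimated at 100000 nM, between 30000 nM and 400000 nM.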

Compound 3, half-maximal inhibitory concentration: > 100000 nM
Compound 3: only a limit was reported; the forecaster's own chance of this, stated with the estimate: 80%; the middle value lies on the limit itself.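

In this assay, among these compounds, compound 3, like compound 1, gives only a limit, so no step between them can be read: the limit of > 100000 nM in this assay, at which 3 of the 3 values shown sit. The compounds shown leave open how strongly any of them inhibits, and whether hydroxy in place of chloro changes that.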